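The source may hold more compounds than are shown below. What is called first, only, known or untested is meant among the compounds shown, and "the series" means these compounds.

Working notes on the series in a functional assay on SMMC-7721 cells (Homo sapiens) for inhibition, read by CCK-8 assay, with a stated time of 72 h, tested at 2 uM; a lower number here means less inhibition of growth, a higher number more inhibition of growth at the concentration tested. Within the data shown here, compound 1 `CCc1ccc(SCc2ccc(/C=C/C(=O)Nc3ccccc3N)cc2)cc1` gives 13.2% and compound 2 `Cc1ccc(SCc2ccc(/C=C/C(=O)Nc3ccccc3N)cc2)cc1` gives 22%, so compound 2 lies within the scatter of compound 1, and these are the only two numbers available. The next structure is compound 3 `Nc1ccccc1NC(=O)/C=C/c1ccc(CSc2ccc(F)cc2)cc1`, with fluoro in place of methyl on an aromatic carbon, para to a large group: fluoro in place of methyl on an aromatic carbon. The group thus changes from 4-methylphenyl to 4-fluorophenyl. Among the measured compounds shown here, the only measured step, a number 8.8 percentage points higher from compound 1 to compound 2 (within the scatter), is hydrogen in place of methyl on a saturated chain carbon and stays within the scatter. For the measured compounds named here, it bears on this change only indirectly, and no measured compound carries fluoro. No step beyond the scatter is therefore expected in this assay. The expected step is a number 2 percentage points lower from compound 2 to compound 3 (within the scatter). For compound 3 the estimated value is 20%, with an expected range of 6% to 38%.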

Compound 3, percent growth inhibition at one concentration: 18.3%
For compound 3 the middle estimate is 1.7 percentage points above the measured one; measured number inside the range.
By their numbers in this assay, from the lowest: compounds 1, 3 and 2 (each within the scatter of the next).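

In this assay, the aromatic carbon para to a large group now takes a non-carbon substituent, and fluoro in place of methyl gives a number 3.7 percentage points lower from compound 2 to compound 3 (within the scatter) while fluoro in place of ethyl gives a number 5.1 percentage points higher from compound 1 to compound 3 (within the scatter) at the same carbon. Neither step leaves the scatter, so fluoro, methyl and ethyl cannot be ordered at this position, and exchanging carbon substituents for fluoro shows no separable effect on growth inhibition at the concentration tested. No supporting data bear on these numbers.

From the compounds shown here alone, what an amine, a methoxy group or a carboxylic acid would give at this carbon stays open, as does the result with plain hydrogen there. Whether a longer chain or a trifluoromethyl group would produce a step beyond the scatter also remains unanswered.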